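Urea series: tert-butyl to fluoro on the anilide ring

This account rests on a few compounds, and the source may have more. Where it says the series, first, only, none or still open, it means among the compounds named here.

Measured so far in an ADME assay on the whole organism with Oryza sativa as the target, tested at 0.1 uM; on this read-out higher numbers stand for a weaker effect at the one concentration tested and lower numbers for a stronger effect:
compound 1, `C[C@@H](NC(=O)Nc1ccccc1C(C)(C)C)c1ccccc1`, 100%
compound 2, `C[C@H](NC(=O)Nc1ccccc1C(C)(C)C)c1ccccc1`, 101%

Compound 1 gives the lower of the two numbers, and compound 2 sits next to it at a number 1 percentage points higher from compound 1 to compound 2 (within the scatter). That step rests on (the fact that compounds 1 and 2 differ only in the configuration as drawn), so the two numbers are read as one level rather than as a difference.

Compound 3, `C[C@@H](NC(=O)Nc1ccccc1F)c1ccccc1`, has not been measured in this assay. It differs from compound 1 by fluoro in place of tert-butyl on an aromatic carbon. Among the measured compounds shown here, no measured step touches a change on that aromatic carbon; the only step on record is the configurational one, which stays within the scatter and gives no lead on the size or direction of a change at the substituent.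

For the measured compounds named here, with both measured numbers at the same level and no step bearing on the replacement, no change beyond the scatter is expected for compound 3, so its value is estimated at 98%, in the range 82% to 110%. The expected step from the parent is a number 2 percentage points lower from compound 1 to compound 3 (within the scatter).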

Compound 3, a percentage reported as activity, at one concentration (the size of the read-out at that concentration, not a potency): 97%
Compound 3: the middle estimate sits 1 percentage points above what was measured; the measured number falls inside the stated range.
By their numbers in this assay, from the lowest: compounds 3, 1 and 2 (each within the scatter of the next).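

At this aromatic carbon, this assay gives for fluoro in place of tert-butyl a number 3 percentage points lower from compound 1 to compound 3 (within the scatter). Among the compounds shown here, the earlier pair probed configuration only, whereas this step is the first on record to change a substituent, and going from 4 heavy atoms to 1 heavy atom leaves the read-out at one level at the one concentration tested. Nothing on record offers a cause for this step.

From the compounds shown here alone, whether an amine or a carboxylic acid on this aromatic carbon would move the number beyond the scatter remains open. Also open, going by these compounds, are whether fluoro gives the same level with the stereocentre drawn S, as in compound 2, and whether compound 1 and compound 3 would stay level at other concentrations.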